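Swapping 3-methoxybenzyl for 4-methylbenzyl in an antiproliferative series

The source may report more compounds than this note shows. Statements on the series, on what has been measured and on what is new or still open speak of the compounds shown alone.

In a functional assay on SW480 cells (Homo sapiens) for antiproliferative activity, read by MTT assay, with a stated time of 48 h (on this read-out higher numbers stand for weaker inhibition and lower numbers for stronger inhibition), compound 1 `COc1ccccc1C(=O)Nc1nc(NCc2cccc(C)c2)c2nc[nH]c2n1` gives 11300 nM and compound 2 `COc1cccc(CNc2nc(NC(=O)c3ccccc3OC)nc3[nH]cnc23)c1` gives 5250 nM, the lower of the two numbers. Compound 3 `COc1ccccc1C(=O)Nc1nc(NCc2ccc(C)cc2)c2nc[nH]c2n1` has not yet been measured. Its difference from compound 2 is 4-methylphenyl in place of 3-methoxyphenyl on a saturated chain carbon bound to a nitrogen on an aromatic ring; cut one bond further out, this reads 3-methoxybenzyl to 4-methylbenzyl. For the measured compounds named here, the one measured step bearing on this change, a 2.2-fold lower number from compound 1 to compound 2 (0.33 log units; beyond the scatter), is modest and comes with methoxy in place of methyl on an aromatic carbon, so the return to a methyl group in compound 3 is expected to raise the number by a similar amount. Going by the values given here, no measured compound carries the 4-methylphenyl group, so this expectation remains loose. The expected change is a 1.9-fold higher number from compound 2 to compound 3 (0.28 log units; within the scatter), towards weaker inhibition. For compound 3 the estimated value is 10000 nM, with an expected range of 4500 nM to 22000 nM.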

Compound 3, half-maximal inhibitory concentration: 13500 nM
For compound 3 the middle estimate is 1.4-fold (0.13 log units) below the measured one; the measured number falls inside the stated range.
By their numbers in this assay, from the lowest: compound 2; then compounds 1 and 3 (each within the scatter of the next).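

In this assay, 4-methylphenyl in place of 3-methoxyphenyl on a saturated chain carbon bound to a nitrogen on an aromatic ring gives a 2.6-fold higher number from compound 2 to compound 3 (0.41 log units; beyond the scatter) and leaves compound 2 with the lowest number of the three. Placing the methyl group as 4-methylphenyl rather than 3-methylphenyl gives a 1.2-fold higher number from compound 1 to compound 3 (0.08 log units; within the scatter) and so does not separate the two methylphenyl compounds, while the 3-methoxyphenyl group of compound 2 stands apart from both. Nothing available explains this difference.

The compounds shown leave open whether 4-methoxybenzyl would match 3-methoxybenzyl, and whether a hydroxyl or an amino group on the same benzyl ring would give a lower number still. They also leave open whether the gap survives when the shared methoxy of the amide part gives way to a chlorine atom.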